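Pyrazole ring methyl to isopropyl: expectation for compound 4

The source may hold more compounds than are shown below. What is called first, only, known or untested is meant among the compounds shown, and "the series" means these compounds.

The series shares a core carrying an aryloxy group and an oxime ether, and is followed in a functional assay on A549 cells (Homo sapiens) for antiproliferative activity, tested at 1 uM; a lower number here means less inhibition, a higher number more inhibition at the concentration tested (going by the name of the read-out). Compound 1 `Cc1nn(-c2ccccc2)c(Oc2ccc(Cl)cc2)c1/C=N/OCc1ccc(C(=O)OC(C)(C)C)cc1` gives -6.5% there. Compound 3 `CCOC(=O)c1ccc(CO/N=C/c2c(C)nn(-c3ccccc3)c2Oc2ccc(Cl)cc2)cc1` gives -9.9% in this assay, and compound 2 `CCOC(=O)c1ccc(CO/N=C/c2c(C)nn(C)c2Oc2ccc(Cl)cc2)cc1` gives 48.2%. Among the three numbers compound 1 stands second highest; its nearest neighbour is compound 3, a number within the scatter of it, as the step of a number 3.4 percentage points lower from compound 1 to compound 3 (within the scatter) shows, while compound 2 lies furthest from it and beyond the scatter. Among the compounds with values here, the one large step seen so far is a number 58.1 percentage points lower from compound 2 to compound 3 (beyond the scatter).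

Compound 4 `CC(C)c1nn(-c2ccccc2)c(Oc2ccc(Cl)cc2)c1/C=N/OCc1ccc(C(=O)OC(C)(C)C)cc1` differs from compound 1 by isopropyl in place of methyl on an aromatic carbon. Neither measured step touches this position: the ester step is within the scatter, and the large step concerns the group on the aromatic nitrogen, not the methyl on the aromatic carbon. Within the data shown here, no measured step therefore bears on the change from compound 1 to compound 4, and the expected step in this assay is none beyond the scatter, as a number 2.5 percentage points higher from compound 1 to compound 4 (within the scatter) expresses. Among the measured compounds shown here, for compound 4 the estimated value in this assay is -4%, expected to fall between -25% and 20%, the range held wide because no measured compound varies the substituent on the aromatic carbon.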

Compound 4, a percentage reported as inhibition, at one concentration (the size of the read-out at that concentration, not a potency): -10.6%
Compound 4: middle estimate off by 6.6 percentage points, on the high side; measured number inside the range.
By their numbers in this assay, from the lowest: compounds 4, 3 and 1 (each within the scatter of the next); then compound 2.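

In this assay, within the data shown here, the exchange of methyl (1 heavy atom) for isopropyl (3 heavy atoms) on this aromatic carbon gives a number 4.1 percentage points lower from compound 1 to compound 4 (within the scatter) and is the first reading at this position. With phenyl on the ring nitrogen and the tert-butyl ester held constant, the larger group brings no gain in inhibition that can be told from the scatter: compound 1 stands at -6.5% and compound 4 at -10.6%, both negative, so this background has little inhibition to lose and the level step cannot show whether the number would stay level where inhibition is higher. No measurement on hand explains the reading.

Open, going by these compounds, is whether isopropyl would read the same with methyl on the ring nitrogen, the setting of compound 2 at 48.2%, where there is inhibition that could fall. Open too is how an amine or a hydroxymethyl group on this aromatic carbon would read, since the only groups shown there so far are methyl and isopropyl.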